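This account rests on a few compounds, and the source may have more. Where it says the series, first, only, none or still open, it means among the compounds named here.

Measured compounds in this series:
- compound 1, `CC(C)(C)c1ccc(C(=O)N2CCC3(CC2)C(=O)N(CC(=O)N2CCNCC2)CN3c2ccccc2)cc1`: 22000 nM
- compound 2, `CC(C)(C)OC(=O)NCCCCNC(=O)CN1CN(c2ccccc2)C2(CCN(C(=O)c3ccc(C4CCCCC4)cc3)CC2)C1=O`: 4600 nM
- compound 3, `CCc1nn(CC)c(C2CCN(C(=O)CN3CN(c4ccccc4)C4(CCN(C(=O)c5ccc(C6CCCCC6)cc5)CC4)C3=O)CC2)c1C`: "not determined" (no result reported)

In an assay on HEK293 cells for displacement of a labelled ligand from NPC1-like intracellular cholesterol transporter 1 (Homo sapiens) (on this read-out lower numbers stand for stronger inhibition and higher numbers for weaker inhibition), compound 1 gives 22000 nM, the highest of the two numbers available. Compound 2 gives 4600 nM in this assay, a lower number; the two structures differ in more than one place, so only the two values themselves can be compared here. Compound 3 carries no number in this assay.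

Compound 4, `CC(C)(C)c1ccc(C(=O)N2CCC3(CC2)C(=O)N(CC(=O)NCNS(C)(=O)=O)CN3c2ccccc2)cc1`, is yet to be measured. It differs from compound 1 in one place: ((methanesulfonamido)methyl)amino in place of piperazin-1-yl on a carbonyl carbon. Going by the values given here, no step between measured compounds covers this kind of change, so the expectation rests on compound 1 alone. The step from compound 1 to compound 4 in this assay is expected to stay within the scatter, a 1.1-fold higher number from compound 1 to compound 4 (0.06 log units; within the scatter), with no direction claimed. For compound 4 the estimated value in this assay is 25000 nM, with a range from 8000 nM to 80000 nM.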

Compound 4, half-maximal inhibitory concentration: 3200 nM
Compound 4: the middle estimate sits 7.8-fold (0.89 log units) above what was measured, and the stated range ends above it.
By their numbers in this assay, from the lowest: compounds 4 and 2 (each within the scatter of the next); then compound 1.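

In this assay, the group on a carbonyl carbon clearly matters: ((methanesulfonamido)methyl)amino in place of piperazin-1-yl gives a 6.9-fold lower number from compound 1 to compound 4 (0.84 log units; beyond the scatter) as a modest step beyond the scatter. The six-membered ring of piperazin-1-yl is therefore not required at this position for the core of compound 1, since the entering group has no ring and still carries the lower number. The change also moves the counts from 1 to 2 hydrogen-bond donors and from 1 to 2 hydrogen-bond acceptors, but no available data link the step to a cause.

From the compounds shown here alone, it remains open which part of the entering group carries the step. A simple amine, a carboxylic acid or a longer alkyl chain on the same carbonyl carbon would separate the methanesulfonamide from the loss of the ring.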